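Bromo added to the phenyl ester of the nitro compound

A few compounds are considered here, and "the series" means these few. Any claim that something is new, unique, unknown or untested is made for them only; others in the source may bear on it.

Compound 3 `O=C(Oc1ccccc1)c1cc2cc([N+](=O)[O-])ccc2oc1=O` gives 76.7% in a functional assay on HT-1080 cells (Homo sapiens), read by transwell migration, with a stated time of 24 h, tested at 1 uM (a higher number here means a weaker effect of the compound at the concentration tested, a lower number a stronger effect), the highest of the three numbers shown. Among the compounds with values here, compound 1 `CCC(=O)OCc1ccc2oc(=O)c(C(=O)Oc3cccc(Br)c3)cc2c1` gives 40.2% and compound 2 `CC(C)C(=O)OCc1ccc2oc(=O)c(C(=O)Oc3cccc(Br)c3)cc2c1` gives 37.8%, both beyond the scatter below compound 3, but these two differ from compound 3 in more than one place, so no single step links them. Compound 4 `O=C(Oc1cccc(Br)c1)c1cc2cc([N+](=O)[O-])ccc2oc1=O` differs from compound 3 by bromo in place of hydrogen on an aromatic carbon. Within the data shown here, the only measured step, a number 2.4 percentage points lower from compound 1 to compound 2 (within the scatter), concerns a saturated chain carbon, not an aromatic carbon, and does not bear on this change. Among the measured compounds shown here, no measured step therefore supports a prediction in either direction, and no step beyond the scatter is expected. Compound 4 is estimated at 70%, range 45% to 92%, meaning an expected step of a number 6.7 percentage points lower from compound 3 to compound 4 (within the scatter).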

Compound 4, a percentage reported as activity, at one concentration (the size of the read-out at that concentration, not a potency): 35.2%
Estimate against measurement, compound 4: 34.8 percentage points above; the whole stated range lies above it.
By their numbers in this assay, from the lowest: compounds 4, 2 and 1 (each within the scatter of the next); then compound 3.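

Bromo in place of hydrogen on this aromatic carbon, meta to a large group, gives a large change in this assay (a number 41.5 percentage points lower from compound 3 to compound 4 (beyond the scatter)), which the earlier step on the saturated chain did not show. Once the 3-bromophenoxy ester is present, nitro in place of the ((isopropylcarbonyl)oxy)methyl or (propanoyloxy)methyl group leaves the read-out unresolved (a number 2.6 percentage points lower from compound 2 to compound 4 (within the scatter); a number 5 percentage points lower from compound 1 to compound 4 (within the scatter)). No evidence explains the size of the bromo step.

As far as these compounds go, whether bromo gives a step of this size alongside either ester-bearing methyl group remains open. So does whether chloro, methoxy or an amine on the same carbon would match bromo.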